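From Benzyl to 2-Methylphenyl on the Ring Nitrogen

The compounds below may be only part of what the source reports. "The series", "measured", "known", "first", "only" and "open" are said of these compounds alone.

Of the compounds shown here, three have so far been measured in a functional assay on the whole organism (strain Swiss albino) with Mus musculus as the target, in the maximal electroshock model, with a stated time of 2 h; a higher number here means that more compound is needed for the effect, a lower number that less compound is needed. Compound 1 `NN1C(=O)C(c2ccccc2)CC(c2ccccc2)C1=O` gives 10 mg/kg. Compound 2 `CN1C(=O)C(c2ccccc2Cl)CC(c2ccccc2Cl)C1=O`, which carries two 2-chlorophenyl groups, gives 23.7 mg/kg. Compound 3 `O=C1C(c2ccccc2Cl)CC(c2ccccc2Cl)C(=O)N1Cc1ccccc1` gives 38.3 mg/kg, the highest of the three numbers; its nearest neighbour is compound 2, at a distance within the scatter, and its furthest is compound 1, whose number lies beyond the scatter below it. Among the measured compounds shown here, the single one-place step among the measured compounds, a 1.6-fold higher number from compound 2 to compound 3 (0.21 log units; within the scatter), left the number within the scatter.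

Compound 4 `Cc1ccccc1N1C(=O)C(c2ccccc2Cl)CC(c2ccccc2Cl)C1=O` is the next candidate. It differs from compound 3 by 2-methylphenyl in place of benzyl on an amide-type nitrogen in a ring. For the measured compounds named here, the only measured step that bears on this position is the one from compound 2 to compound 3, and it stayed within the scatter; compound 1 differs from compound 2 in two places, so its value alone says nothing about the nitrogen. No step beyond the scatter is therefore expected. Compound 4 is expected to give about 35 mg/kg, in a range from 15 mg/kg to 80 mg/kg. This estimate means a step of a 1.1-fold lower number from compound 3 to compound 4 (0.04 log units; within the scatter), which is expected to stay within the scatter.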

Compound 4, dose for half-maximal effect: 27.4 mg/kg
Estimate against measurement, compound 4: 1.3-fold (0.11 log units) above; the range from low to high includes it.
By their numbers in this assay, from the lowest: compound 1; then compounds 2, 4 and 3 (each within the scatter of the next).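

With compound 4, the amide-type nitrogen in a ring has been tested with three groups instead of two: methyl, benzyl and 2-methylphenyl. In this assay, replacing either earlier group with 2-methylphenyl left the number within the scatter, whether from benzyl (a 1.4-fold lower number from compound 3 to compound 4 (0.15 log units; within the scatter)) or from methyl (a 1.2-fold higher number from compound 2 to compound 4 (0.06 log units; within the scatter)). Across these three compounds, therefore, neither the swap between two groups of equal heavy-atom count nor the swap from methyl to an aromatic ring separates the values, and no available evidence explains this.

From the compounds shown here alone, it remains open whether an amine, a carboxylic acid or a longer chain on this nitrogen would move the number beyond the scatter. Compound 1 differs from these compounds in two places, so the separate contributions of its amino group and its unsubstituted phenyl groups also remain unresolved.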